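The source may report more compounds than this note shows. Statements on the series, on what has been measured and on what is new or still open speak of the compounds shown alone.

Measured in a functional assay on HCT-116 cells (Homo sapiens) for antiproliferative activity, read by CCK-8 assay, with a stated time of 72 h; a higher number here means a weaker inhibitor, a lower number a stronger inhibitor:
compound 1 `Cc1cc(Nc2cc(N3CCN(C)CC3)nc(Nc3ccc(S(N)(=O)=O)cc3)n2)n[nH]1`: 12200 nM
compound 2 `Cc1cc(Nc2cc(N3CCN(C)CC3)nc(Nc3cccc([N+](=O)[O-])c3)n2)n[nH]1`: 1820 nM
compound 3 `Cc1cc(Nc2cc(N3CCN(C)CC3)nc(Nc3ccc(C#N)cc3)n2)n[nH]1`: 650 nM

Compound 3 has the lowest number of the three, and both of its gaps lie beyond the scatter. The gap to its nearest neighbour is a 2.8-fold lower number from compound 2 to compound 3 (0.45 log units; beyond the scatter), and the gap to its furthest is a 19-fold lower number from compound 1 to compound 3 (1.27 log units; beyond the scatter).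

The next compound, compound 4 `COc1ccc(Nc2nc(Nc3cc(C)[nH]n3)cc(N3CCN(C)CC3)n2)cc1`, keeps the shared core and changes a single group: methoxy in place of cyano on an aromatic carbon. That is methoxy in place of cyano on an aromatic carbon, para to a large group.

The most relevant measured change is a 19-fold lower number from compound 1 to compound 3 (1.27 log units; beyond the scatter), which also exchanges the group at this place and was large. The other two steps replace the whole aryl group and were modest: a 6.7-fold lower number from compound 1 to compound 2 (0.83 log units; beyond the scatter) and a 2.8-fold lower number from compound 2 to compound 3 (0.45 log units; beyond the scatter). Together they show that this part of the structure moves the number in this assay. Among the measured compounds shown here, no measured compound carries methoxy, so the direction rests on thin evidence. Compound 3 already holds the lowest of the three values, so a higher number seems the likelier outcome.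

The expected change is modest and upward: a 1.5-fold higher number from compound 3 to compound 4 (0.19 log units; within the scatter).

The estimated value for compound 4 is 1000 nM, with an expected range of 300 nM to 4000 nM.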

Compound 4, half-maximal inhibitory concentration: 2240 nM
The estimate for compound 4 lay 2.2-fold (0.35 log units) below the measured number; low and high end bracket the measured number.
By their numbers in this assay, from the lowest: compound 3; then compounds 2 and 4 (each within the scatter of the next); then compound 1.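

In this assay, the step from cyano to methoxy on this aromatic carbon, para to a large group, gives a 3.4-fold higher number from compound 3 to compound 4 (0.54 log units; beyond the scatter), even though both groups count 2 heavy atoms, no ring and 1 hydrogen-bond acceptor, so these counts alone do not set the number at this place. Methoxy in place of sulfamoyl gives a 5.4-fold lower number from compound 1 to compound 4 (0.74 log units; beyond the scatter), which places three groups at this same carbon in one series: compound 3, with cyano, has the lowest number, compound 1, with sulfamoyl, has the highest, and compound 4, with methoxy, falls in between. The change of the whole aryl group gives a 1.2-fold higher number from compound 2 to compound 4 (0.09 log units; within the scatter), so the 4-methoxyphenyl of compound 4 and the 3-nitrophenyl of compound 2 cannot be told apart in this assay, although they differ in both the group and its place on the ring.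

The compounds shown offer no measurement that accounts for the gap between cyano and methoxy. As far as these compounds go, it remains open how an amine, a carboxylic acid or a longer chain such as ethoxy would fare on this carbon, and whether cyano would keep its number at another place on the ring.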